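This account rests on a few compounds, and the source may have more. Where it says the series, first, only, none or still open, it means among the compounds named here.

Of the compounds shown here, three sharing one core have been tested in a functional assay on DU-145 cells (Homo sapiens) for inhibition, read by trypan blue exclusion, with a stated time of 96 h; a lower number here means a stronger inhibitor of growth, a higher number a weaker inhibitor of growth. Compound 1, `Cc1cc(C)cc(/C=C(\C(=O)c2ccc(Cl)cc2)S(=O)(=O)c2ccc(Br)cc2)c1`, gives 10000 nM in this assay. Compound 2, `O=C(/C(=C\c1c(O)cc(O)cc1O)S(=O)(=O)c1ccccc1Br)c1ccc(Cl)cc1`, gives 50000 nM in this assay, and compound 3, `CC(=O)c1ccc(/C=C(/Sc2ccc(C)cc2)C(=O)c2ccc(Br)cc2)cc1`, gives 50000 nM in this assay. Compound 1 therefore stands with the lowest number of the three, and its gap to each of the other two lies beyond the usual scatter of repeated measurements, so among these three it is the strongest inhibitor of growth. For the measured compounds named here, compound 2 and compound 3 each differ from compound 1 in more than one place, so no single structural step between measured compounds is available to lean on.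

The next compound, compound 4, `O=C(/C(=C\c1ccccc1F)S(=O)(=O)c1ccc(Br)cc1)c1ccc(Cl)cc1`, differs from compound 1 in just one place: 2-fluorophenyl in place of 3,5-dimethylphenyl on a double-bonded chain carbon bound to a double-bonded chain carbon. The measured compounds show nothing about this particular exchange on its own. None of them makes it in isolation. With no guide from the data, the expected step in this assay is small, none beyond the scatter or at most a modest drift in either direction. Compound 4 is therefore estimated to give about 15000 nM in this assay, with a plausible range from 4000 nM to 50000 nM. The expected step is a 1.5-fold higher number from compound 1 to compound 4 (0.18 log units; within the scatter).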

Compound 4, concentration for 50% growth inhibition: 25000 nM
For compound 4 the middle estimate is 1.7-fold (0.22 log units) below the measured one; measured number inside the range.
By their numbers in this assay, from the lowest: compound 1; then compounds 4, 2 and 3 (each within the scatter of the next).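

In this assay, for the compounds shown here, this is the first exchange in a single place, and it shows that the position is not indifferent to what sits there. With 2-fluorophenyl in place of 3,5-dimethylphenyl on a double-bonded chain carbon bound to a double-bonded chain carbon, the step is a 2.5-fold higher number from compound 1 to compound 4 (0.40 log units; beyond the scatter) and lies beyond the usual scatter, so this modest change gives a weaker inhibitor of growth even though both groups are built on a six-membered aromatic ring of carbon only and count no hydrogen-bond donors or acceptors. Nothing available explains this loss.

This single exchange removes two methyl groups and adds a fluorine at once, so it cannot show how much of the step belongs to each change. The compounds shown also leave open what an unsubstituted phenyl, or a phenyl carrying an amine or a carboxylic acid, would do at this position, and whether the same exchange would give a similar step with the other parts of the core changed.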